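A few compounds are considered here, and "the series" means these few. Any claim that something is new, unique, unknown or untested is made for them only; others in the source may bear on it.

Working notes on the series. In a functional assay on SW1573 cells (Homo sapiens) for antiproliferative activity, read by sulforhodamine B assay, with a stated time of 48 h (a higher number here means a weaker inhibitor of growth, a lower number a stronger inhibitor of growth), compound 1 `CCCCCCC(C#CC(=O)O)O/C=C/C(=O)OC` gives > 100000 nM, which is a limit of the assay and not a number. Among the measured compounds shown here, compound 2 `CCCCCC(C#CC(=O)OC)O/C=C/C(=O)OC` gives 1700 nM, the only actual number so far, so it has no numerical neighbour against which to rank it.

The next entry is compound 3 `CCCCCCC(C#CC(=O)OC)O/C=C/C(=O)OC`, which differs from compound 2 by methyl in place of hydrogen on a saturated chain carbon, six bonds along the chain from an oxygen on an unsaturated carbon and a triple-bonded carbon. The same difference can also be read as propyl to butyl, one bond further out.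

For the measured compounds named here, no measured pair isolates a change of this kind, so the expectation starts from compound 2 at 1700 nM, with a wide margin. In this assay, the expected step of a 1.2-fold lower number from compound 2 to compound 3 (0.08 log units; within the scatter) is small, with no shift beyond the scatter in either direction. The estimated value for compound 3 is 1400 nM, with an expected range from 450 nM to 4500 nM.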

Compound 3, concentration for 50% growth inhibition: 3300 nM
For compound 3 the middle estimate is 2.4-fold (0.37 log units) below the measured one, and the stated range covers the measured number.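

In this assay, the step from propyl to butyl at this saturated chain carbon gives a 1.9-fold higher number from compound 2 to compound 3 (0.29 log units; within the scatter), so compound 2 and compound 3 cannot be told apart at this position. Among the compounds shown here, the other comparison now available, methyl in place of hydrogen on an oxygen next to a carbonyl group, gives the first step beyond the scatter: an at least 30-fold lower number from compound 1 to compound 3 (1.48 log units; beyond the scatter). Compound 1 gives > 100000 nM, which is a limit of the assay and not a number, so that step gives only a bound and not a true size: the limit of > 100000 nM in this assay, at which 1 of the 3 values shown sits.

A longer chain, a branched chain or a phenyl ring on the saturated chain remains open, and the two chain lengths shown give no trend that could be extended to such groups. Also open, as far as these compounds go, is whether an ethyl group or an amide nitrogen in place of the methyl on the oxygen next to a carbonyl group would keep the number of compound 3 or move it towards that of compound 1.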